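The source may report more compounds than this note shows. Statements on the series, on what has been measured and on what is new or still open speak of the compounds shown alone.

Of the compounds shown here, three with the same shared core have been tested so far, differing only in the group that hangs from the amide-type nitrogen of the side chain. Compound 1 `CCOC(=O)C1=C(C)NC(C)=C(C(=O)OCC)C1c1ccc(OCC(=O)NCc2ccccc2)cc1` gives 16.1% in a functional assay on the whole organism (strain Wistar) for inhibition, with Rattus norvegicus as the target, read by paw edema, with stated times of 30 min and 1 h, at a dose of 20 mg/kg; on this read-out higher numbers stand for more inhibition at the one dose given (going by the name of the read-out) and lower numbers for less inhibition. Compound 2 `CCOC(=O)C1=C(C)NC(C)=C(C(=O)OCC)C1c1ccc(OCC(=O)Nc2ccc(C)cc2)cc1` gives 55.1% in this assay. Compound 3 `CCOC(=O)C1=C(C)NC(C)=C(C(=O)OCC)C1c1ccc(OCC(=O)NNC(=O)c2ccccc2)cc1` gives 29.5% in this assay, which places it second highest of the three numbers: the move a number 13.4 percentage points higher from compound 1 to compound 3 (beyond the scatter), while the move a number 25.6 percentage points lower from compound 2 to compound 3 (beyond the scatter).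

Compound 4 `CCOC(=O)C1=C(C)NC(C)=C(C(=O)OCC)C1c1ccc(OCC(=O)NNC(=O)c2sccc2Cl)cc1` keeps everything of compound 3 except one change: 3-chlorothiophen-2-yl in place of phenyl on a carbonyl carbon. Going by the values given here, no measured step touches this carbonyl carbon; every step so far swaps the group on the amide-type nitrogen, and those swaps moved the read-out by as much as a number 39 percentage points higher from compound 1 to compound 2 (beyond the scatter), so this end of the molecule does respond to changes. Among the compounds with values here, with no direct precedent for exchanging the ring on the carbonyl, the expectation is a small step, not clearly beyond the scatter, in this assay. Compound 4 is therefore estimated at about 32%, with a likely range from 18% to 48%. This estimate corresponds to an expected step of a number 2.5 percentage points higher from compound 3 to compound 4 (within the scatter).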

Compound 4, a percentage reported as inhibition, in the whole organism at one dose (the size of the read-out at that dose, not a potency): 39.7%
Compound 4: middle estimate off by 7.7 percentage points, on the low side; measured number inside the range.
By their numbers in this assay, from the lowest: compound 1; then compound 3; then compound 4; then compound 2.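

The ring on the carbonyl carbon matters in this assay: with the rest of the molecule held fixed, 3-chlorothiophen-2-yl in place of phenyl gives a number 10.2 percentage points higher from compound 3 to compound 4 (beyond the scatter), which shows that a change on this carbonyl carbon, and not only a swap on the amide-type nitrogen, can move the read-out beyond the scatter. Read as whole groups on that nitrogen, ((3-chlorothiophen-2-yl)carbonyl)amino gives a number 23.6 percentage points higher from compound 1 to compound 4 (beyond the scatter) and also a number 15.4 percentage points lower from compound 2 to compound 4 (beyond the scatter), so it sits above benzyl but does not match 4-methylphenyl. No available evidence bears on why this exchange raises the number.

The exchange replaces a six-membered carbon ring with a five-membered ring holding a sulfur and also brings in a chlorine, so the compounds shown cannot tell which part carries the step; a plain thiophen-2-yl or a chlorophenyl on the same carbonyl would separate the two. Also open, going by these compounds, is whether other groups here, such as a pyridine ring or a simple methyl, would hold this level or come closer to compound 2.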